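Swapping a Naphthyl Ring for a Fluoro-Methoxyphenyl Ring

The compounds below may be only part of what the source reports. "The series", "measured", "known", "first", "only" and "open" are said of these compounds alone.

Compound 1 `CC(C)N(Cc1cccc(OCCCCCC(=O)O)c1)C(=O)c1ccc(-c2ccc(Cl)c(Cl)c2)cc1` gives > 26000 nM in an ADME assay on Raji cells (Homo sapiens) for cytotoxicity, read by CellTiter-Glo and resazurin assay, with a stated time of 72 h (on this read-out lower numbers stand for an effect already at smaller amounts and higher numbers for an effect only at larger amounts of compound), which is a limit of the assay rather than a number.
Compound 2 `CC(C)N(Cc1cccc(OCCCCCC(=O)O)c1)C(=O)c1ccc(-c2cccc(Cl)c2)cc1` gives > 21900 nM in this assay, again only a limit.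
Compound 3 `CCOC(=O)CCCCCOc1cccc(CN(C(=O)c2ccc(-c3cccc4ccccc34)cc2)C(C)C)c1` gives > 26000 nM in this assay, also a limit.

Compound 3 therefore stands at a limit, and so does every other value shown: across the set, two values sit at the limit of > 26000 nM in this assay, at which 2 of the 3 values shown sit, and one at the limit of > 21900 nM in this assay, at which 1 of the 3 values shown sits. For the measured compounds named here, no compound reached a readable number.

Compound 4 `CCOC(=O)CCCCCOc1cccc(CN(C(=O)c2ccc(-c3cc(F)cc(OC)c3)cc2)C(C)C)c1` differs from compound 3 by 3-fluoro-5-methoxyphenyl in place of naphthalen-1-yl on an aromatic carbon. Going by the values given here, the only measured step in the set, a step that the two limits leave unreadable from compound 1 to compound 2, concerns a different change and, because both of its ends are limits, its size cannot be read. Among the compounds with values here, no measured step bears on an exchange of the naphthalen-1-yl group, so there is nothing to suggest a step beyond the scatter in this assay in either direction.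

Compound 4 is therefore expected to sit at about 30000 nM, most likely reported again as a limit, with a plausible range from 12000 nM to 80000 nM. The step that the limit leaves unreadable from compound 3 to compound 4 expected from this estimate is essentially none.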

Compound 4, half-maximal effective concentration: > 26000 nM
Compound 4 ended at the assay's limit (the forecaster's own chance of this, stated with the estimate: 85%); the middle value does not contradict the limit.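

Compound 3 and compound 4 both sit at a limit of this assay, and no step can be read for the exchange of naphthalen-1-yl for 3-fluoro-5-methoxyphenyl. The compounds shown leave open at what concentration, if any, each of them would reach a half-maximal effect.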